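This account rests on a few compounds, and the source may have more. Where it says the series, first, only, none or still open, it means among the compounds named here.

Measured so far in a functional assay on HEK293 cells for activation of melanin-concentrating hormone receptor 1 (Rattus norvegicus), read by inositol phosphate accumulation; on this read-out lower numbers stand for an effect already at smaller amounts and higher numbers for an effect only at larger amounts of compound:
- compound 1 `O=C(CCc1ccc(C(F)(F)F)cc1)Nc1ccc2nc(N3CCC3)ccc2c1` gives 56 nM
- compound 2 `CN(c1ccc2cc(NC(=O)CCc3ccc(C(F)(F)F)cc3)ccc2n1)C1CCCC1` gives 350 nM
- compound 3 `CC1CCN(c2ccc3cc(NC(=O)CCc4ccc(C(F)(F)F)cc4)ccc3n2)C1` gives 400 nM

Compound 2 stands second highest of the three; its nearest neighbour is compound 3, a 1.1-fold higher number from compound 2 to compound 3 (0.06 log units; within the scatter), while compound 1 lies furthest, a 6.3-fold higher number from compound 1 to compound 2 (0.80 log units; beyond the scatter). Compound 4 `CCN(CC)c1ccc2cc(NC(=O)CCc3ccc(C(F)(F)F)cc3)ccc2n1` differs from compound 2 in one place: diethylamino in place of cyclopentyl(methyl)amino on an aromatic carbon. Among the compounds with values here, the steps that bear on this are a 6.3-fold higher number from compound 1 to compound 2 (0.80 log units; beyond the scatter) and a 7.1-fold higher number from compound 1 to compound 3 (0.85 log units; beyond the scatter), both modest and both running the same way when the azetidin-1-yl group is exchanged for a larger amine. Diethylamino lies between azetidin-1-yl and cyclopentyl(methyl)amino in size, so compound 4 is expected to give a somewhat lower number than compound 2, a 1.8-fold lower number from compound 2 to compound 4 (0.24 log units; within the scatter). The estimate for compound 4 in this assay is 200 nM, within 70 nM to 600 nM.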

Compound 4, half-maximal effective concentration: 830 nM
For compound 4 the middle estimate is 4.2-fold (0.62 log units) below the measured one, and the stated range ends below it.
By their numbers in this assay, from the lowest: compound 1; then compounds 2 and 3 (each within the scatter of the next); then compound 4.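

In this assay, losing the cyclopentyl ring does not bring the number back towards that of compound 1: diethylamino, with fewer heavy atoms than cyclopentyl(methyl)amino, raises it (a 2.4-fold higher number from compound 2 to compound 4 (0.38 log units; beyond the scatter)). It also stands apart from 3-methylpyrrolidin-1-yl (a 2.1-fold higher number from compound 3 to compound 4 (0.32 log units; beyond the scatter)) and furthest from azetidin-1-yl (a 15-fold higher number from compound 1 to compound 4 (1.17 log units; beyond the scatter)), so compound 4 goes against any ordering of these amines by heavy-atom count alone. Nothing available here accounts for this result.

Open, on these data alone, is where dimethylamino or piperidin-1-yl would stand at this position. Also open, as far as these compounds go, is whether the low number of compound 1 belongs to azetidin-1-yl alone.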